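The compounds below may be only part of what the source reports. "The series", "measured", "known", "first", "only" and "open" are said of these compounds alone.

Measured so far in a functional assay on HCT-116 cells (Homo sapiens) for cytotoxicity, with a stated time of 48 h (on this read-out higher numbers stand for weaker inhibition and lower numbers for stronger inhibition), are two compounds:
- compound 1 `COc1cc(OC)c(C(=O)/C=C/c2ccc(Cl)cc2)c(OC)c1` at 5400 nM
- compound 2 `COc1cc(OC)c(C(=O)/C=C/c2ccc(F)cc2)c(OC)c1` at 6200 nM

Compound 2 at 6200 nM stands within the scatter of compound 1 at 5400 nM and the two cannot be ordered. The step to compound 3 `COc1cc(OC)c(C(=O)/C=C/c2ccc([N+](=O)[O-])cc2)c(OC)c1` puts nitro in place of fluoro on an aromatic carbon, para to a large group (nitro in place of fluoro on an aromatic carbon). Among the measured compounds shown here, the only measured step at this place (a 1.1-fold higher number from compound 1 to compound 2 (0.06 log units; within the scatter)) is fluoro in place of chloro, and it lies within the scatter. For the measured compounds named here, no measured compound carries nitro, so this single step is a thin guide. No step beyond the scatter is expected in this assay, and no clear direction is expected, though the range is kept wide. The expected change is small (a 1.1-fold lower number from compound 2 to compound 3 (0.05 log units; within the scatter)). Compound 3 is estimated at 5500 nM, with an expected range from 2000 nM to 15000 nM for repeated measurements.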

Compound 3, half-maximal inhibitory concentration: 2700 nM
Estimate against measurement, compound 3: 2.0-fold (0.31 log units) above; the range from low to high includes it.
By their numbers in this assay, from the lowest: compounds 3, 1 and 2 (each within the scatter of the next, the first and the last beyond it).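

In this assay the place on the aromatic carbon, para to a large group, now responds beyond the scatter, which the exchange of chloro for fluoro did not show: nitro in place of fluoro gives a 2.3-fold lower number from compound 2 to compound 3 (0.36 log units; beyond the scatter) and this step is modest. Nitro in place of chloro gives a 2.0-fold lower number from compound 1 to compound 3 (0.30 log units; within the scatter) and so compound 3 cannot be ordered against compound 1, which leaves the fluoro comparison as the only one that clears the scatter. Nothing available here accounts for this step.

Going by these compounds, whether an amine, a nitrile or a carboxylic acid at this same place would move the number further, or in the opposite direction, stays open. Also open, on these data alone, is whether the modest step from fluoro to nitro carries over to a different core.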